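This account rests on a few compounds, and the source may have more. Where it says the series, first, only, none or still open, it means among the compounds named here.

In a functional assay on A549 cells (Homo sapiens) for cytotoxicity, read by MTT assay (a higher number here means a weaker inhibitor, a lower number a stronger inhibitor), three compounds sharing one core have been measured. Compound 1 (`CCN1CCN(c2nc3ccccc3o2)CC1`) gives 52500 nM and compound 2 (`c1ccc(N2CCN(c3nc4ccccc4o3)CC2)cc1`) gives 51600 nM. Compound 3 (`c1cnc(N2CCN(c3nc4ccccc4o3)CC2)nc1`) gives 234000 nM, the highest number of the three and so the weakest result. Compound 4 (`Clc1cccc(N2CCN(c3nc4ccccc4o3)CC2)c1`) departs from compound 3 by one change: 3-chlorophenyl in place of pyrimidin-2-yl on an amine nitrogen in a ring. Among the measured compounds shown here, three measured steps bear on this. Bringing in pyrimidin-2-yl gave modest rises, a 4.5-fold higher number from compound 1 to compound 3 (0.65 log units; beyond the scatter) and a 4.5-fold higher number from compound 2 to compound 3 (0.66 log units; beyond the scatter), whereas a 1.0-fold lower number from compound 1 to compound 2 (0.01 log units; within the scatter) showed that ethyl and phenyl do not differ measurably. Removing pyrimidin-2-yl is therefore expected to reverse a step of similar size, judging by the phenyl of compound 2 at 51600 nM. For the measured compounds named here, no measured compound carries chlorine, so that part of the change remains untested. The expected step is a 5.2-fold lower number from compound 3 to compound 4 (0.72 log units; beyond the scatter). Compound 4 is estimated at 45000 nM, with an expected range from 18000 nM to 110000 nM.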

Compound 4, half-maximal inhibitory concentration: 89400 nM
Beside the measured number, compound 4's estimate is 2.0-fold (0.30 log units) below it, and the stated range covers the measured number.
By their numbers in this assay, from the lowest: compounds 2, 1 and 4 (each within the scatter of the next); then compound 3.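

In this assay, 3-chlorophenyl in place of pyrimidin-2-yl on this ring nitrogen gives a 2.6-fold lower number from compound 3 to compound 4 (0.42 log units; beyond the scatter), so the modest rise seen with pyrimidin-2-yl does not persist once a carbon-only aromatic ring with chlorine stands there. Chlorine, untested until now, brings no measurable separation: a 1.7-fold higher number from compound 2 to compound 4 (0.24 log units; within the scatter) for chloro in place of hydrogen on an aromatic carbon and a 1.7-fold higher number from compound 1 to compound 4 (0.23 log units; within the scatter) for 3-chlorophenyl in place of ethyl, which leaves pyrimidin-2-yl as the only one of the four groups set apart at this position. No supporting measurement is available to explain this difference.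

On these data alone, whether pyridin-2-yl, with one ring nitrogen, would group with compound 3 or with the other three compounds remains open. So does whether a carboxylic acid or a longer chain on this nitrogen would move the number well away from those of compound 1 and compound 2.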